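From 4-bromophenyl to 3-bromophenyl in an antiproliferative series

This account rests on a few compounds, and the source may have more. Where it says the series, first, only, none or still open, it means among the compounds named here.

Values measured in a functional assay on HCT-116 cells (Homo sapiens) for antiproliferative activity, read by MTT assay, with a stated time of 72 h; on this read-out higher numbers stand for weaker inhibition and lower numbers for stronger inhibition
Compound 1 `O=C(CCc1cccc2c1B(O)OC2)NC1CCCCC1` gives > 100000 nM (a limit of the assay)
Compound 2 `O=C(CCc1cccc2c1B(O)OC2)Nc1ccc(F)cc1` gives 650 nM
Compound 3 `O=C(CCc1cccc2c1B(O)OC2)Nc1ccc(Br)cc1` gives 46000 nM

Among the two actual numbers in this assay, compound 3 holds the higher, at 46000 nM. Its nearest neighbour is compound 2, with a 71-fold higher number from compound 2 to compound 3 (1.85 log units; beyond the scatter). Compound 1 reports only a limit, so it takes no exact place in this order.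

Compound 4 `O=C(CCc1cccc2c1B(O)OC2)Nc1cccc(Br)c1` has 3-bromophenyl in place of 4-bromophenyl on an amide-type nitrogen. Within the data shown here, no measured step makes this kind of change, so the evidence is only indirect. The closest step is the large one of bromo in place of fluoro on an aromatic carbon, a 71-fold higher number from compound 2 to compound 3 (1.85 log units; beyond the scatter), which shows how far one swap on the phenyl group can move the number in this pair. Replacing cyclohexyl gave an at least 150-fold lower number from compound 1 to compound 2 (2.18 log units; beyond the scatter) with 4-fluorophenyl, a large step. The same replacement gave an at least 2.1-fold lower number from compound 1 to compound 3 (0.33 log units; beyond the scatter) with 4-bromophenyl, a step of at least modest size.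

Compound 3 sits at the high end of the two phenyl amides, with compound 2 at 650 nM, so a moderate move toward lower numbers is expected, though with wide uncertainty. The expected change is a 3.1-fold lower number from compound 3 to compound 4 (0.49 log units; beyond the scatter). For compound 4 the estimated value is 15000 nM, with an expected range from 2500 nM to 70000 nM.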

Compound 4, half-maximal inhibitory concentration: 1400 nM
The estimate for compound 4 lay 11-fold (1.03 log units) above the measured number; the whole stated range lies above it.
By their numbers in this assay, from the lowest: compound 2; then compound 4; then compound 3. At a limit, above all of these: compound 1.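

In this assay the same atoms joined differently give a large step, a 33-fold lower number from compound 3 to compound 4 (1.52 log units; beyond the scatter), so in this pair the place of the bromo group on the phenyl ring, and not merely its presence, sets the number. Bromo as such does not carry the weak number of compound 3, for 3-bromophenyl stays near 4-fluorophenyl, with a 2.2-fold higher number from compound 2 to compound 4 (0.33 log units; beyond the scatter), a modest step though still beyond the scatter. Against cyclohexyl, 3-bromophenyl gives an at least 71-fold lower number from compound 1 to compound 4 (1.85 log units; beyond the scatter), but this step is only a bound, and compound 1 reports a limit of the assay rather than a number: the limit of > 100000 nM in this assay, at which 1 of the 4 values shown sits.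

The compounds shown leave open whether the lower number seen with 3-bromophenyl carries over to 3-chlorophenyl, 3-methoxyphenyl or 3-aminophenyl on the same amide-type nitrogen. They also leave open whether a longer chain linking the shared core to the amide carbonyl would keep the large difference seen between 3-bromophenyl and 4-bromophenyl.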